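This account rests on a few compounds, and the source may have more. Where it says the series, first, only, none or still open, it means among the compounds named here.

Of the compounds shown here, two have been measured in a functional assay on SF-539 cells (Homo sapiens) for inhibition, read by sulforhodamine B assay, with a stated time of 48 h, tested at 1 uM; a higher number here means a weaker effect of the compound at the concentration tested, a lower number a stronger effect. Compound 1 `O=C(Nc1cccc(-n2cc(-c3ccncc3)c(-c3cc(O)cc(Cl)c3)n2)c1)Nc1ccc(Cl)c(Cl)c1` gives 72% in this assay. Compound 2 `COc1cc(Cl)cc(-c2nn(-c3cccc(NC(=O)Nc4cc(C(F)(F)F)cc(C(F)(F)F)c4)c3)cc2-c2ccncc2)c1` gives 59%, the lower of the two numbers, and it stands apart from compound 1 by a gap that lies beyond the usual scatter. Compound 3 `COc1cc(Cl)cc(-c2nn(-c3cccc(NC(=O)Nc4cccc(C(F)(F)F)c4)c3)cc2-c2ccncc2)c1` has not yet been measured. It differs from compound 2 in one place: hydrogen in place of trifluoromethyl on an aromatic carbon. For the measured compounds named here, no measured pair shows this same change, so its size in this assay cannot be read from the data. Starting from compound 2 at 59%, the step of a number 7 percentage points higher from compound 2 to compound 3 (within the scatter) is expected to be small and, if anything, toward a higher number, close to the edge of the scatter. For compound 3 the estimated value is 66%, with a range from 48% to 84%.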

Compound 3, a percentage reported as activity, at one concentration (the size of the read-out at that concentration, not a potency): 84%
Estimate against measurement, compound 3: 18 percentage points below; measured number inside the range.
By their numbers in this assay, from the lowest: compound 2; then compound 1; then compound 3.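

In this assay, for the compounds shown here, the change of trifluoromethyl to hydrogen gives a number 25 percentage points higher from compound 2 to compound 3 (beyond the scatter) and is the first single-place change that can be read in this set. It shows that this aromatic carbon, meta to a trifluoromethyl group, matters here: with hydrogen on it the effect at the tested concentration is weaker, so the second trifluoromethyl group goes with the stronger effect of this pair. No measurement at hand accounts for the size of this step.

Going by these compounds, whether a smaller group such as a nitrile or a methyl, or an amine, on this carbon would stay near compound 2 or near compound 3 remains open. Also open, on these data alone, is whether the same change would have a step of similar size with the hydroxyl group of compound 1 in place of the methoxy group.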